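Compound 1 to compound 3: isopropylcarbamoyl to ethylcarbamoyl

The compounds below may be only part of what the source reports. "The series", "measured", "known", "first", "only" and "open" are said of these compounds alone.

Within the data shown here, in a functional assay on MCF7 cells (Homo sapiens) for antiproliferative activity, read by CCK-8 assay, with a stated time of 72 h (on this read-out higher numbers stand for weaker inhibition of growth and lower numbers for stronger inhibition of growth), compound 1 `CCC1C(=O)N(C)c2cnc(-n3ccc4cc(C(=O)NC(C)C)ccc43)nc2N1c1ccn(C)n1` gives 8420 nM, the only number so far. Compound 2 `CC[C@@H]1C(=O)N(C)c2cnc(-n3ccc4cc(F)ccc43)nc2N1C1CCCC1` gives "not active" (no number reported), so it offers no number for comparison. Compound 3 `CCNC(=O)c1ccc2c(ccn2-c2ncc3c(n2)N(c2ccn(C)n2)C(CC)C(=O)N3C)c1` differs from compound 1 by hydrogen in place of methyl on a saturated chain carbon bound to an amide-type nitrogen and a saturated chain carbon, which reads as isopropylcarbamoyl to ethylcarbamoyl. Among the measured compounds shown here, no measured pair shows this change. The expected step in this assay is a 1.1-fold lower number from compound 1 to compound 3 (0.02 log units; within the scatter), in neither direction beyond the scatter. For compound 3 the estimate is 8000 nM, with an expected range from 3000 nM to 22000 nM.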

Compound 3, concentration for 50% growth inhibition: 13200 nM
Compound 3: middle estimate off by 1.7-fold (0.22 log units), on the low side, and the stated range covers the measured number.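

In this assay, among these compounds, the change from isopropylcarbamoyl to ethylcarbamoyl gives a 1.6-fold higher number from compound 1 to compound 3 (0.20 log units; within the scatter) as the first readable step. At this position, removing one methyl from the saturated chain carbon therefore produces no difference beyond the scatter. Nothing measured on these compounds accounts for this result.

A single step cannot show whether this position stays as flat with a longer chain on the carbamoyl nitrogen. Also open, going by these compounds, is the effect of an amine or a carboxylic acid there.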